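A few compounds are considered here, and "the series" means these few. Any claim that something is new, unique, unknown or untested is made for them only; others in the source may bear on it.

Among the compounds with values here, compound 2 `CC(=O)OCc1cc(N)c(Nc2ccc(C#N)cc2)cc1Oc1c(C)cc(CCC#N)cc1C` stands at the higher of the two numbers measured: in a physicochemical assay for lipophilicity, read by HPLC, measured as octanol-water partition, with a stated time of 24 h, at pH 7.4 (on this read-out higher numbers stand for higher lipophilicity and lower numbers for lower lipophilicity), compound 2 gives 2.84, while compound 1 `Cc1cc(CCC#N)cc(C)c1Oc1cc(Nc2ccc(C#N)cc2)c(N)cc1C(=O)NC1CC1` gives 2.61, and the single measured step is a number 0.23 log units higher from compound 1 to compound 2 (within the scatter). Compound 3 `Cc1cc(CCC#N)cc(C)c1Oc1cc(Nc2ccc(C#N)cc2)c(N)cc1COC(=O)C1CC1` differs from compound 2 by cyclopropyl in place of methyl on a carbonyl carbon. Within the data shown here, no measured step touches the carbonyl carbon; the one step known changed a different part of the structure and stayed within the scatter, so it offers little guidance for this change. With methyl giving way to cyclopropyl on the carbonyl carbon, and no donor or acceptor entering or leaving, a rise in this assay beyond the scatter is expected. The step from compound 2 to compound 3 is estimated at a number 0.61 log units higher from compound 2 to compound 3 (beyond the scatter). Compound 3 is therefore expected to give 3.45, with a range from 3.1 to 3.8.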

Compound 3, partition coefficient: 2.51
The estimate for compound 3 lay 0.94 log units above the measured number; measured number outside the range, below it.
By their numbers in this assay, from the lowest: compounds 3, 1 and 2 (each within the scatter of the next, the first and the last beyond it).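

In this assay, cyclopropyl in place of methyl on a carbonyl carbon gives a number 0.33 log units lower from compound 2 to compound 3 (beyond the scatter) and is the only step among the compounds shown that passes beyond the scatter, so this position responds to a change that adds carbon and no hydrogen-bond donor or acceptor, and here the number goes down. With ((cyclopropylcarbonyl)oxy)methyl in place of cyclopropylcarbamoyl on an aromatic carbon, the read-out gives a number 0.10 log units lower from compound 1 to compound 3 (within the scatter) and does not separate these two groups. No measurement at hand accounts for the direction of the step at the carbonyl carbon.

As far as these compounds go, a single pair speaks for this place, so it stays open whether the lower number belongs to cyclopropyl alone or also appears with a longer chain such as propyl or a larger ring such as cyclohexyl. From the compounds shown here alone, how an amine or a carboxylic acid on the carbonyl carbon would read also remains open.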